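Swapping a Propoxy Chain for a Cyclopentyloxy Ring

A few compounds are considered here, and "the series" means these few. Any claim that something is new, unique, unknown or untested is made for them only; others in the source may bear on it.

Measured so far:
Compound 1, `CC(C(=O)NCc1ccc(C(C)(C)C)nc1SCCCN1CCCC1)c1ccc(NS(C)(=O)=O)c(F)c1`: 17.1 nM
Compound 2, `CCCOc1cc(C(C)(C)C)ccc1CNC(=O)C(C)c1ccc(NS(C)(=O)=O)c(F)c1`: 4.4 nM

Of the compounds shown here, two have been tested in an assay on cells for antagonist activity at transient receptor potential cation channel subfamily V member 1 (Homo sapiens), read by FLIPR and calcium flux, with a stated time of 6 min; a lower number here means a stronger inhibitor, a higher number a weaker inhibitor. Compound 1 gives 17.1 nM. Compound 2 gives 4.4 nM, the lower of the two numbers, and its gap to compound 1 is larger than the usual scatter of repeated measurements, so compound 2 is the stronger inhibitor of the pair.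

Compound 3, `CC(C(=O)NCc1ccc(C(C)(C)C)cc1OC1CCCC1)c1ccc(NS(C)(=O)=O)c(F)c1`, has not yet been measured. It differs from compound 2 at one spot: cyclopentyl in place of propyl on an oxygen on an aromatic ring. Going by the values given here, no measured pair in this set shows the effect of such a change, so there is no step to lean on. Since the two compounds otherwise share everything, the change is expected to move the number only modestly, with the step of a 1.1-fold higher number from compound 2 to compound 3 (0.06 log units; within the scatter) likely within or near the scatter. Compound 3 is therefore estimated at 5 nM in this assay, with a plausible range from 1.5 nM to 16 nM.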

Compound 3, inhibition constant: 1.8 nM
Beside the measured number, compound 3's estimate is 2.8-fold (0.44 log units) above it; measured number inside the range.
By their numbers in this assay, from the lowest: compound 3; then compound 2; then compound 1.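

In this assay, changing propoxy to cyclopentyloxy gives a 2.4-fold lower number from compound 2 to compound 3 (0.39 log units; beyond the scatter), a modest step but one beyond the usual scatter. Going by these compounds alone, this is the first direct read on this position, and it shows that the open propyl chain on the oxygen is not required: a five-membered carbon ring with 5 heavy atoms in place of 3 keeps the compound a strong inhibitor and lowers the number. Nothing measured here shows what lies behind this step.

Cyclopentyl is the only ring shown on this oxygen, so it remains open whether cyclobutyl, cyclohexyl or a longer chain such as butyl would lower the number further or raise it. The step also rests on a single pair of compounds, so it cannot yet be said whether it would hold on a different core.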